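Chains on the aromatic oxygen of the shared core

This account rests on a few compounds, and the source may have more. Where it says the series, first, only, none or still open, it means among the compounds named here.

Compound 3 `O=C(Nc1ccc(C(=O)N2CCCCc3sccc32)cc1O)c1ccccc1-c1ccccc1` carries a hydrogen on the aromatic oxygen. In an assay on CHO cells for inhibition of Vasopressin V2 receptor (Homo sapiens), read by radioligand binding (a lower number here means a stronger inhibitor, a higher number a weaker inhibitor), compound 3 reaches only a limit of the assay, < 10 nM, and this is the limit of < 10 nM in this assay, at which 1 of the 3 values shown sits. Compound 1 `O=C(Nc1ccc(C(=O)N2CCCCc3sccc32)cc1OCCCC(=O)N1CCC(N2CCCCC2)CC1)c1ccccc1-c1ccccc1` and compound 2 `CN1CCCN(C(=O)CCCOc2cc(C(=O)N3CCCCc4sccc43)ccc2NC(=O)c2ccccc2-c2ccccc2)CC1` carry chains of the same length on that oxygen: compound 1 gives 30 nM and compound 2 gives 10 nM. The step of a 3.0-fold lower number from compound 1 to compound 2 (0.48 log units; beyond the scatter) shows that the amine at the end of the chain moves the number only modestly. Compound 4 `CN1CCN(C(=O)CCCOc2cc(C(=O)N3CCCCc4sccc43)ccc2NC(=O)c2ccccc2-c2ccccc2)CC1` differs from compound 3 by 3-((4-methylpiperazin-1-yl)carbonyl)propyl in place of hydrogen on an oxygen on an aromatic ring. For the measured compounds named here, no measured step bears directly on replacing that hydrogen: compound 3 shows only a limit. Compounds 1 and 2, both bearing such chains, sit near that limit. Compound 4 is expected to land in the same region, with a step of an at least 1.5-fold higher number from compound 3 to compound 4 (0.17 log units; that floor lies within the scatter) that is small or within the scatter. Compound 4 is estimated at 15 nM, in a range from 5 nM to 45 nM.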

Compound 4, half-maximal inhibitory concentration: 6 nM
Estimate against measurement, compound 4: 2.5-fold (0.40 log units) above; the measured number falls inside the stated range.
By their numbers in this assay, from the lowest: compounds 4 and 2 (each within the scatter of the next); then compound 1.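

In this assay, 4-methylpiperazin-1-yl in place of 4-methyl-1,4-diazepan-1-yl gives a 1.7-fold lower number from compound 2 to compound 4 (0.22 log units; within the scatter), so these two end groups are not told apart. In place of 4-(piperidin-1-yl)piperidin-1-yl, the same group gives a 5.0-fold lower number from compound 1 to compound 4 (0.70 log units; beyond the scatter), so compound 1 now stands apart from both compound 2 and compound 4. Compound 3 stands at a limit, so the step from it to compound 4 cannot be read: the limit of < 10 nM in this assay, at which 1 of the 4 values shown sits.

From the compounds shown here alone, whether the chain costs anything against the free hydrogen stays open. Also open, going by these compounds, is whether a shorter or longer chain on the aromatic oxygen, or a morpholine or carboxylic acid at its end, would hold the number in this region.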